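The source may hold more compounds than are shown below. What is called first, only, known or untested is meant among the compounds shown, and "the series" means these compounds.

In a functional assay on NCI-H522 cells (Homo sapiens) for inhibition, read by sulforhodamine B assay, with a stated time of 48 h, tested at 10 uM (a higher number here means more inhibition of growth at the concentration tested, a lower number less inhibition of growth), compound 1 `CC(=O)c1ccc(NC(=O)Cn2nc(-c3ccc(Cl)cc3)nc2N)cc1` gives 28% and so stands close to its two measured relatives. In the same test compound 2 `C/C(=N\O)c1ccc(NC(=O)Cn2nc(-c3ccc(Cl)cc3)nc2N)cc1` gives 31.5% and compound 3 `COc1cc(-c2nc(N)n(CC(=O)Nc3ccc(/C(C)=N\O)cc3)n2)cc(OC)c1OC` gives 29.2% as its reading. All three numbers lie within the usual scatter of compound 1, so none of them stands apart.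

Compound 4 `CC(=O)c1ccc(NC(=O)Cn2nc(C(F)(F)F)nc2N)cc1` has not yet been measured. It keeps the rest of compound 1, but trifluoromethyl stands in place of 4-chlorophenyl on an aromatic carbon: trifluoromethyl in place of 4-chlorophenyl on an aromatic carbon is the whole change.

Among the measured compounds shown here, the one measured step is a number 3.5 percentage points higher from compound 1 to compound 2 (within the scatter) and it leaves the 4-chlorophenyl untouched, changing a group elsewhere. It therefore says little about this swap, and no measurement shows directly what replacing 4-chlorophenyl does. In this assay the expected outcome is a number 6 percentage points lower from compound 1 to compound 4 (within the scatter) and so no step beyond the scatter, with only a faint lean towards less inhibition of growth. Compound 4 is therefore estimated at 22% within an expected range running from 8% to 38% at this single concentration.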

Compound 4, percent growth inhibition at one concentration: 21%
Compound 4: the middle estimate sits 1 percentage points above what was measured; the range from low to high includes it.
By their numbers in this assay, from the lowest: compounds 4, 1, 3 and 2 (each within the scatter of the next, the first and the last beyond it).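

In this assay the swap at this place gives a number 7 percentage points lower from compound 1 to compound 4 (within the scatter). Among the compounds shown here, this is the first measured change on the aromatic carbon between two ring nitrogen atoms, and it shows that a large step down in size, from 4-chlorophenyl with its six-membered aromatic ring to trifluoromethyl with no ring, does not move the reading beyond the scatter. At this single concentration, then, the aromatic ring at this place is not required for a reading like that of compound 1, and no measured information on the compounds gives a reason for this.

As far as these compounds go, it remains open whether a different group here, such as an amine, a carboxylic acid or a longer carbon chain, would move the reading beyond the scatter. From the compounds shown here alone, it is also open whether trifluoromethyl would behave the same way on the core of compound 2.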